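Moving the chlorine on the phenyl of compound 2

A few compounds are considered here, and "the series" means these few. Any claim that something is new, unique, unknown or untested is made for them only; others in the source may bear on it.

In a physicochemical assay for solubility, read by HPLC, in phosphate buffer, measured as kinetic solubility, at pH 7.4 (a higher number here means a more soluble compound, a lower number a less soluble compound), compound 1 `CC(=O)c1cc(-c2ccc(Cl)cc2)n(-c2ccc(S(N)(=O)=O)cc2)c1C` gives 2700 nM and compound 2 `CCOC(=O)c1cc(-c2ccc(Cl)cc2)n(-c2ccc(S(N)(=O)=O)cc2)c1C` gives 4200 nM, so these two stand within the scatter of each other. Compound 3 `CCOC(=O)c1cc(-c2cccc(Cl)c2)n(-c2ccc(S(N)(=O)=O)cc2)c1C` carries 3-chlorophenyl in place of 4-chlorophenyl on an aromatic carbon. Among the compounds with values here, the only measured step, a 1.6-fold higher number from compound 1 to compound 2 (0.19 log units; within the scatter), concerns a carbonyl carbon, not this aromatic carbon, and it stayed within the scatter. It offers no measured guide to the chlorine change, so no step beyond the scatter is expected in this assay. The expected step is a 1.1-fold lower number from compound 2 to compound 3 (0.02 log units; within the scatter). The estimated value for compound 3 is 4000 nM, with an expected range of 1600 nM to 10000 nM.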

Compound 3, solubility: 9200 nM
Estimate against measurement, compound 3: 2.3-fold (0.36 log units) below, within the range that was stated.
By their numbers in this assay, from the lowest: compounds 1 and 2 (each within the scatter of the next); then compound 3.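

In this assay, 3-chlorophenyl in place of 4-chlorophenyl gives a 2.2-fold higher number from compound 2 to compound 3 (0.34 log units; beyond the scatter), the only step shown that lies beyond the scatter. The leaving and entering groups have the same atoms and the same counts, so where the chlorine sits on the phenyl is enough to separate two compounds in this series. No available evidence accounts for this result. The compounds shown leave open whether an amine or a carboxylic acid in place of the chlorine would shift the number further, and whether moving the chlorine on compound 1 would give a similar step.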